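Swapping the pyrazole for a pyridine on the amide nitrogen

The compounds below may be only part of what the source reports. "The series", "measured", "known", "first", "only" and "open" are said of these compounds alone.

Compound 1 `Cc1ccc(OCC(=O)N(Cc2cccs2)c2c[nH]nc2C)cc1` gives the lowest number of the three measured compounds in an assay on HEK293 cells for agonist activity at transient receptor potential cation channel subfamily M member 8 (Homo sapiens), read by fluorescence and calcium flux, with a stated time of 15 min (a lower number here means that less compound is needed, a higher number that more compound is needed for the effect), with compound 1 at 0.4 nM. Compound 2 `CCN(Cc1cccs1)C(=O)COc1ccc(C)cc1O` reaches 8 nM in this assay, and compound 3 `CCN(Cc1cccs1)C(=O)COc1ccc(CO)cc1` needs far more, at 21900 nM; both gaps to compound 1 lie beyond the usual scatter. Compound 4 `Cc1ccc(OCC(=O)N(Cc2cccs2)c2ccccn2)cc1` has not been measured; it differs from compound 1 in one place (pyridin-2-yl in place of 3-methyl-1H-pyrazol-4-yl on an amide-type nitrogen). Among the compounds with values here, no measured pair shows this change, so the expectation rests on compound 1 alone. A modest loss of potency is expected in this assay, with the step of a 6.3-fold higher number from compound 1 to compound 4 (0.80 log units; beyond the scatter) probably beyond the scatter but uncertain in size. Compound 4 is therefore estimated at 2.5 nM, within a range of 0.3 nM to 25 nM.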

Compound 4, half-maximal effective concentration: 200 nM
Compound 4: middle estimate off by 80-fold (1.90 log units), on the low side, and the stated range ends below it.
By their numbers in this assay, from the lowest: compound 1; then compound 2; then compound 4; then compound 3.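

Exchanging one aromatic ring for another with the same heavy-atom count on the amide-type nitrogen gives a 500-fold higher number from compound 1 to compound 4 (2.70 log units; beyond the scatter) in this assay and so shows that this position is far from indifferent to which ring it carries. The change removes the hydrogen-bond donor, the methyl group and the five-membered ring all at once, and this single step cannot separate them. No measured evidence here explains the loss.

Still open, from the compounds shown here alone, is how a plain phenyl ring, or a 1H-pyrazol-4-yl group without its methyl, would read at this place.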